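The compounds below may be only part of what the source reports. "The series", "measured", "known", "first", "only" and "open" are said of these compounds alone.

Compound 3, `COc1cccc(C2CS(=O)(=O)Oc3c2c(C2CC2)nn3-c2ccccc2F)c1`, gives 2.01 in a physicochemical assay for lipophilicity, using the shake flask method, in phosphate buffer, measured as octanol-water partition, with a stated time of 24 h, at pH 7.4 (a lower number here means a more polar compound, a higher number a more lipophilic compound), the lowest of the three numbers recorded so far. Compound 1, `Cc1cc(C2CS(=O)(=O)Oc3c2c(C2CC2)nn3-c2ccccc2Cl)ccc1Br`, stands nearest to it with 2.53, and compound 2, `O=S1(=O)CC(c2cccc(F)c2)c2c(C3CC3)nn(-c3ccccc3F)c2O1`, furthest with 2.86. Among the measured compounds shown here, the one single-point step among the measured compounds is the exchange of methoxy for fluoro on an aromatic carbon, which gave a number 0.85 log units lower from compound 2 to compound 3 (beyond the scatter), a modest shift beyond the scatter.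

Compound 4, `Cc1cc(C2CS(=O)(=O)Oc3c2c(C2CC2)nn3-c2ccccc2F)ccc1Br`, is reached from compound 3 by 4-bromo-3-methylphenyl in place of 3-methoxyphenyl on a saturated ring carbon. For the measured compounds named here, no measured step covers this exact exchange. The closest guide is compound 1, which carries the same 4-bromo-3-methylphenyl group and differs from compound 4 only on the other aryl ring; compound 1 gives 2.53, well above the value of compound 3. With a fluoro-bearing aryl at this position, paired with the same fluorophenyl as compound 4, compound 2 reaches 2.86. Both comparisons point the same way: a step upward from compound 3, beyond the scatter, of roughly the size seen between compound 3 and compound 1 or compound 2.

The estimated step is therefore a number 0.69 log units higher from compound 3 to compound 4 (beyond the scatter). Compound 4 is expected to give 2.7, with a likely range from 2.2 to 3.2.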

Compound 4, partition coefficient: 2.72
Compound 4: the middle estimate sits 0.02 log units below what was measured; the range from low to high includes it.
By their numbers in this assay, from the lowest: compound 3; then compounds 1, 4 and 2 (each within the scatter of the next, the first and the last beyond it).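

On the saturated ring carbon, the exchange of 3-methoxyphenyl for 4-bromo-3-methylphenyl gives a number 0.71 log units higher from compound 3 to compound 4 (beyond the scatter) in this assay and is the second step beyond the scatter that starts from compound 3. The exchange of 3-fluorophenyl for 4-bromo-3-methylphenyl at the same carbon gives a number 0.14 log units lower from compound 2 to compound 4 (within the scatter) and so does not separate these two groups, which leaves 3-methoxyphenyl as the only one of the three aryl groups compared there that stands apart. The other aryl ring now gets a step of its own, as fluoro in place of chloro on an aromatic carbon gives a number 0.19 log units higher from compound 1 to compound 4 (within the scatter) with no separation between the two halogens, and nothing measured here accounts for any of these steps.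

The compounds shown carry only aryl groups on the saturated ring carbon, so how an amine, a carboxylic acid or a longer chain at that carbon would read in this assay stays open. They also do not separate the bromo from the methyl within 4-bromo-3-methylphenyl, since the two enter together as one group.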